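The source may hold more compounds than are shown below. What is called first, only, known or untested is meant among the compounds shown, and "the series" means these compounds.

Measured so far in a functional assay for antagonist activity at Alpha-1A adrenergic receptor (Oryctolagus cuniculus); a lower number here means tighter binding, a higher number weaker binding:

- compound 1 `CNC(=O)c1cccnc1NCCCN1CCN(c2ccccc2OC)CC1`: 1 nM
- compound 2 `COc1ccccc1N1CCN(CCCNc2ccncc2C(=O)N(C)C)CC1`: 12.6 nM
- compound 3 `CN(C)C(=O)c1cccnc1NCCCN1CCN(c2ccccc2OCC(F)(F)F)CC1`: 0.1 nM

Compound 3 gives the lowest number of the three. Its nearest neighbour on the numbers is compound 1, whose value is higher by a gap that lies beyond the scatter; compound 2 is furthest off, again beyond the scatter. No pair among these three differs in a single place, so no measured step is available to calibrate the next change.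

Compound 4 `CN(C)C(=O)c1cccnc1NCCCN1CCN(c2ccccc2C2CC2)CC1` is not yet measured. It is built from compound 3 by one change:

cyclopropyl in place of 2,2,2-trifluoroethoxy on an aromatic carbon

Among the measured compounds shown here, with no single-point step to lean on, only the position of compound 3 and the nature of the swap guide the expectation. The change removes the only hydrogen-bond acceptor of the leaving group and brings in a small ring. The step from compound 3 to compound 4 is expected to be a 5.0-fold higher number from compound 3 to compound 4 (0.70 log units; beyond the scatter), a modest move towards a higher number, possibly within the scatter. For compound 4 the estimate in this assay is 0.5 nM, with a range from 0.1 nM to 3 nM.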

Compound 4, dissociation constant: 0.631 nM
Estimate against measurement, compound 4: 1.3-fold (0.10 log units) below; the measured number falls inside the stated range.
By their numbers in this assay, from the lowest: compound 3; then compounds 4 and 1 (each within the scatter of the next); then compound 2.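

In this assay the series now has its first single-place calibration, a 6.3-fold higher number from compound 3 to compound 4 (0.80 log units; beyond the scatter), for cyclopropyl in place of 2,2,2-trifluoroethoxy on an aromatic carbon ortho to a large group. The position accepts an all-carbon ring with no hydrogen-bond acceptor and fewer heavy atoms, and compound 4 keeps a low number at 0.631 nM, although the step lies beyond the scatter. Nothing available explains the size of this step.

With a single pair at this position, the contributions of the oxygen, the fluorines and the ring cannot be told apart, and an isopropyl or ethoxy group on the same core would address that. From the compounds shown here alone, compounds 1 and 2 each differ from compound 3 in more than one place, so the effects of the amide and its placement also remain open.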